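The source may hold more compounds than are shown below. What is called first, only, known or untested is meant among the compounds shown, and "the series" means these compounds.

Compound 1, `Cc1cccc(-c2n[nH]cc2N2CCCNCC2)c1`. In an assay on isolated protein for binding affinity to 5-hydroxytryptamine receptor 1E (Homo sapiens) (a lower number here means a stronger inhibitor, a higher number a weaker inhibitor), compound 1 gives > 10000 nM, which is a limit of the assay and not a number.
Compound 2, `COc1ccccc1-c1n[nH]cc1N1CCCNCC1`. In this assay compound 2 gives > 10000 nM, again a limit.
Compound 3, `COc1ccc(-c2n[nH]cc2N2CCCNCC2)cc1`. In this assay compound 3 gives > 10000 nM, also a limit.

Compound 3 thus stands at the limit of this assay, and the other two values shown are limits as well, so all three sit at the limit of > 10000 nM in this assay, at which 3 of the 3 values shown sit. Among the compounds with values here, nothing in these numbers sets compound 3 apart from compound 1 or compound 2, and no step between measured compounds can be given. Compound 4, `c1ccc(-c2n[nH]cc2N2CCCNCC2)cc1`, remains to be measured in this assay. It differs from compound 3 in one place: hydrogen in place of methoxy on an aromatic carbon. Within the data shown here, no measured step exists against which the size of this change could be read, and the three measured compounds, which carry different groups on the same kind of ring, all reach no number. The expected step from compound 3 to compound 4 is a step that the limit leaves unreadable from compound 3 to compound 4, no larger than the scatter. For compound 4 the estimate in this assay is 20000 nM, between 5000 nM and 100000 nM, and the most likely outcome is expected to be once more a limit rather than a number.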

Compound 4, inhibition constant: > 10000 nM
Compound 4: no number, only a limit; the forecaster's own chance of this, stated with the estimate: 80%; the middle value is on the limit's open side.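

In this assay compound 4 gives > 10000 nM as a limit and not a number. Within the data shown here, no step can therefore be read between compound 4 and compound 1, compound 2 or compound 3, since all four stand at the same limit: the limit of > 10000 nM in this assay, at which 4 of the 4 values shown sit. The compounds shown leave open whether any change to the shared core gives a number in this assay rather than a limit.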